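The compounds below may be only part of what the source reports. "The series", "measured", "known", "first", "only" and "open" are said of these compounds alone.

Measured compounds in the series:

Compound 1, `COc1cc(-n2cnc3ccc(-c4cccc(N)c4)cc32)cc(OC)c1OC`: 21 nM
Compound 2, `COc1cc(-n2cnc3ccc(-c4ccc(C(F)(F)F)cc4)cc32)cc(OC)c1OC`: 890 nM
Compound 3, `COc1cc(-n2cnc3ccc(-c4ccc(F)cc4)cc32)cc(OC)c1OC`: 3500 nM

All three share one core and differ only in the aryl group on the fused ring. In a functional assay on SGC-7901 cells (Homo sapiens) for antiproliferative activity, read by MTT assay, with a stated time of 72 h (a lower number here means a stronger inhibitor, a higher number a weaker inhibitor), compound 1 gives the lowest number of the three. Compound 3 stands at the highest number: against compound 2 it is a 3.9-fold higher number from compound 2 to compound 3 (0.59 log units; beyond the scatter), and against compound 1 it is a 170-fold higher number from compound 1 to compound 3 (2.22 log units; beyond the scatter).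

The next compound is compound 4, `COc1cc(-n2cnc3ccc(-c4cccc(O)c4)cc32)cc(OC)c1OC`. Relative to compound 3 the change is 3-hydroxyphenyl in place of 4-fluorophenyl on an aromatic carbon.

Among the measured compounds shown here, no measured step swaps these two groups directly. For the measured compounds named here, the steps that bear on it are a 170-fold higher number from compound 1 to compound 3 (2.22 log units; beyond the scatter) and a 42-fold higher number from compound 1 to compound 2 (1.63 log units; beyond the scatter): in both, leaving a 3-aminophenyl for a para-substituted phenyl gave a large rise in the number. Compound 4 carries a 3-hydroxyphenyl, a group that, like 3-aminophenyl in compound 1, brings one hydrogen-bond donor and one acceptor. A large step downward in this assay is therefore expected, reversing much of the gap between compound 3 and compound 1, though the step is not expected to reach the full extent seen for compound 1, since no measurement of a hydroxyl here exists. The estimated step is a 44-fold lower number from compound 3 to compound 4 (1.64 log units; beyond the scatter). For compound 4 the expected value in this assay is 80 nM, with a range from 20 nM to 400 nM.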

Compound 4, half-maximal inhibitory concentration: 53 nM
The estimate for compound 4 lay 1.5-fold (0.18 log units) above the measured number; the range from low to high includes it.
By their numbers in this assay, from the lowest: compound 1; then compound 4; then compound 2; then compound 3.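

In this assay the low numbers at this position are not confined to the 3-aminophenyl of compound 1: 3-hydroxyphenyl gives a 66-fold lower number from compound 3 to compound 4 (1.82 log units; beyond the scatter) and also a 17-fold lower number from compound 2 to compound 4 (1.23 log units; beyond the scatter) in the same direction. Amino and hydroxy are still not equivalent on this ring, with a 2.5-fold higher number from compound 1 to compound 4 (0.40 log units; beyond the scatter) printed as beyond the scatter, though this modest step is small beside the two large ones. The entering 3-hydroxyphenyl counts 1 hydrogen-bond donor and 1 hydrogen-bond acceptor where the leaving 4-fluorophenyl counts 0 of each, but the substituent and its place on the ring change together in this step, and the data tie the drop to neither alone. No measurement at hand accounts for any of these steps.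

Still open, on these data alone, is whether the substituent or its place on the ring carries the effect: 3-fluorophenyl and 4-hydroxyphenyl would pull the two apart. Also open, as far as these compounds go, is whether the hydroxy hydrogen itself counts, which 3-methoxyphenyl would address, and whether a group such as 3-carboxyphenyl would keep the number as low.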